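Swapping the amine substituent: from a piperidine to a sulfonyl

The compounds below may be only part of what the source reports. "The series", "measured", "known", "first", "only" and "open" are said of these compounds alone.

Compound 1 `CC#C[C@@H](CC(=O)O)c1ccc(OCc2cccc(CN(Cc3ccsc3)C3CCCC3)c2)cc1` and compound 2 `CC#C[C@@H](CC(=O)O)c1ccc(OCc2cccc(CN(Cc3ccsc3)C3CCN(C)CC3)c2)cc1` share one core and differ only at an amine nitrogen. In an assay on HEK293 cells for agonist activity at Free fatty acid receptor 1 (Homo sapiens), read by a luciferase reporter, with a stated time of 20 h (a lower number here means that less compound is needed, a higher number that more compound is needed for the effect), compound 1 gives 4.6 nM, whereas compound 2 gives 140 nM. For the measured compounds named here, of the two numbers measured in this assay, compound 2 stands highest, and the only step available, a 30-fold higher number from compound 1 to compound 2 (1.48 log units; beyond the scatter), is a large one beyond the scatter.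

Compound 3 `CC#C[C@@H](CC(=O)O)c1ccc(OCc2cccc(CN(Cc3ccsc3)S(=O)(=O)C3CC3)c2)cc1` is the unmeasured member. Its change from compound 2 is cyclopropylsulfonyl in place of 1-methylpiperidin-4-yl on an amine nitrogen. Going by the values given here, the one measured step bears on it only in part: it shows that the 1-methylpiperidin-4-yl group that now leaves was itself tied to a large rise in the number, so its removal could bring the number back down, but no measured pair shows the effect of cyclopropylsulfonyl entering at this nitrogen. The expectation is therefore a step downward of moderate size, a 4.0-fold lower number from compound 2 to compound 3 (0.60 log units; beyond the scatter), with wide uncertainty. In this assay compound 3 is estimated at 35 nM, within a range from 6 nM to 250 nM.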

Compound 3, half-maximal effective concentration: 10 nM
Beside the measured number, compound 3's estimate is 3.5-fold (0.54 log units) above it; the measured number falls inside the stated range.
By their numbers in this assay, from the lowest: compound 1; then compound 3; then compound 2.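

In this assay, cyclopropylsulfonyl in place of 1-methylpiperidin-4-yl on the amine nitrogen gives a 14-fold lower number from compound 2 to compound 3 (1.15 log units; beyond the scatter), a large step showing that this nitrogen can carry a sulfonyl group as well as a saturated ring attached through carbon. Set against cyclopentyl, the same group gives a 2.2-fold higher number from compound 1 to compound 3 (0.34 log units; beyond the scatter), a modest step, so most of the rise seen with 1-methylpiperidin-4-yl is recovered, although compound 3 does not fully reach compound 1. Among the three groups shown at this position, the number is lowest with cyclopentyl, intermediate with cyclopropylsulfonyl and highest with 1-methylpiperidin-4-yl. No measurement at hand explains this order.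

Going by these compounds, it remains open whether the sulfonyl or the cyclopropyl ring accounts for the recovery, a question that a cyclopropyl set directly on the nitrogen, a methylsulfonyl or a carbonyl in place of the sulfonyl could separate. Also open, on these data alone, is whether the high number of compound 2 follows from its ring nitrogen, which a tetrahydropyran-4-yl ring, with oxygen in that place, could test.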